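From benzyl to 4-methoxyphenyl: notes on compound 4

A few compounds are considered here, and "the series" means these few. Any claim that something is new, unique, unknown or untested is made for them only; others in the source may bear on it.

- compound 1 `O=C(CCCCCNc1c(NCc2ccccc2)c(=O)c1=O)NO` gives 75000000 nM
- compound 2 `CC(C)(Nc1c(NCCCCCC(=O)NO)c(=O)c1=O)c1ccccc1` gives 88000000 nM
- compound 3 `Cc1ccccc1[C@H](C)Nc1c(NCCCCCC(=O)NO)c(=O)c1=O` gives 92000000 nM

These three values come from a physicochemical assay for solubility, read by HPLC, in phosphate buffer, with a stated time of 24 h, at pH 7.4, tested at 100 uM (on this read-out lower numbers stand for lower solubility and higher numbers for higher solubility), and lie within the scatter of one another. Compound 1 therefore cannot be told apart from compound 2 or compound 3 on these numbers, and no ranking can be drawn. Going by the values given here, no two measured compounds differ in one place only, so the series offers no direct step to read.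

Still unmeasured is compound 4 `COc1ccc(Nc2c(NCCCCCC(=O)NO)c(=O)c2=O)cc1`, which shares the core of compound 1 and has 4-methoxyphenyl in place of benzyl on a nitrogen on an aromatic ring. Compound 2 at 88000000 nM and compound 3 at 92000000 nM carry other groups in that place and remain within the scatter of compound 1. On that basis, no step beyond the scatter is expected in this assay. Among the compounds with values here, no measured compound carries 4-methoxyphenyl, so the expected range stays wide, and three values give no firm direction.

The expected change is a 1.2-fold lower number from compound 1 to compound 4 (0.06 log units; within the scatter), a small one.

For compound 4 the estimated value is 65000000 nM, with an expected range from 30000000 nM to 100000000 nM.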

Compound 4, solubility: 3300000 nM
The estimate for compound 4 lay 20-fold (1.29 log units) above the measured number; the measured number lies below the stated range.
By their numbers in this assay, from the lowest: compound 4; then compounds 1, 2 and 3 (each within the scatter of the next).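

In this assay, going by these compounds alone, the group on this nitrogen turns out to matter: the change to 4-methoxyphenyl gives a 23-fold lower number from compound 1 to compound 4 (1.36 log units; beyond the scatter) and is the first step that clears the scatter. The three earlier values sat within the scatter of one another and gave no sign that this place could move the read-out so far; a single exchange, with 8 heavy atoms entering for 7 and 1 hydrogen-bond acceptor entering for 0, now shows that it can. No supporting measurement accompanies the series, so the step stands as an observation with no cause attached.

Within the data shown here, with only this one pair, the step cannot be divided between the methoxy oxygen and the aromatic ring sitting directly on the nitrogen, and a plain phenyl or a 4-methoxybenzyl group at this place would be needed to pull those two apart. From the compounds shown here alone, it also remains open whether a 4-hydroxyphenyl, a 4-fluorophenyl or a ring carrying a carboxylic acid or an amine would stay with compound 1 or fall with compound 4.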